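This account rests on a few compounds, and the source may have more. Where it says the series, first, only, none or still open, it means among the compounds named here.

Measured so far:
Compound 1, `FC(F)(F)c1ccc(CSc2nc(N3CCCCC3)c3ccccc3n2)cc1`, in a functional assay on MDA-MB-231 cells (Homo sapiens) for cytotoxicity, read by MTT assay, with a stated time of 72 h (a higher number here means a weaker inhibitor, a lower number a stronger inhibitor), compound 1 gives 28400 nM.
Compound 2, `FC(F)(F)c1ccc(CSc2nc(Nc3cccc(C(F)(F)F)c3)c3ccccc3n2)cc1`, in this assay compound 2 gives 11100 nM.

Compound 2 stands with the lowest of the two numbers shown; the nearest is compound 1, and the only measured step is a 2.6-fold lower number from compound 1 to compound 2 (0.41 log units; beyond the scatter), a change of the whole group on the shared core. Compound 3, `FC(F)(F)c1ccc(CSc2nc(Nc3ccc(C(F)(F)F)cc3)c3ccccc3n2)cc1`, differs from compound 2 by 4-(trifluoromethyl)phenyl in place of 3-(trifluoromethyl)phenyl on a nitrogen on an aromatic ring. Within the data shown here, no measured step bears on this change directly: the step from compound 1 to compound 2 exchanges one amine for another and says nothing about where the trifluoromethyl sits on the phenyl. With nothing in the numbers to lean on either way, the expected step in this assay is none beyond the scatter, a 1.0-fold lower number from compound 2 to compound 3 (0.00 log units; within the scatter). Compound 3 is therefore estimated at 11000 nM, with a range from 4000 nM to 30000 nM.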

Compound 3, half-maximal inhibitory concentration: 5460 nM
Estimate against measurement, compound 3: 2.0-fold (0.30 log units) above; the range from low to high includes it.
By their numbers in this assay, from the lowest: compound 3; then compound 2; then compound 1.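

In this assay, placing 4-(trifluoromethyl)phenyl instead of 3-(trifluoromethyl)phenyl on the same nitrogen gives a 2.0-fold lower number from compound 2 to compound 3 (0.31 log units; beyond the scatter), so with the same atoms joined differently, the place of the trifluoromethyl on the phenyl ring matters, which the earlier pair could not show. Measured against piperidin-1-yl, (4-(trifluoromethyl)phenyl)amino gives a 5.2-fold lower number from compound 1 to compound 3 (0.72 log units; beyond the scatter), a larger step than the earlier 2.6-fold lower number from compound 1 to compound 2 (0.41 log units; beyond the scatter) with (3-(trifluoromethyl)phenyl)amino. Nothing available explains the difference between these two groups.

The compounds shown leave open whether the trifluoromethyl itself matters, which a plain phenyl, a 4-chlorophenyl or a 4-methoxyphenyl on the same nitrogen could test. They also say nothing about changes to the 4-(trifluoromethyl)benzyl group shared by all three compounds.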